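Changing the Ring at the End of the Chain

This account rests on a few compounds, and the source may have more. Where it says the series, first, only, none or still open, it means among the compounds named here.

Among the compounds with values here, compound 2 `O=C(/C=C/c1cccc(O)c1)c1cccc(-n2cc(-c3ccc(Cl)cc3)[nH]c2=O)c1` gives 1600 nM in a functional assay on HOP-92 cells (Homo sapiens) for inhibition (a lower number here means a stronger inhibitor of growth, a higher number a weaker inhibitor of growth), the lowest of the two numbers measured so far. Within the data shown here, compound 1 `O=C(/C=C/c1cccc(O)c1)c1cccc(-n2cc(-c3ccccc3)[nH]c2=O)c1` gives 5040 nM in this assay, and the one measured step, a 3.2-fold lower number from compound 1 to compound 2 (0.50 log units; beyond the scatter), came from a chloro in place of hydrogen on the other aromatic ring. Compound 3 `COc1cc(/C=C/C(=O)c2cccc(-n3cc(-c4ccc(Cl)cc4)[nH]c3=O)c2)ccc1O` differs from compound 2 by 4-hydroxy-3-methoxyphenyl in place of 3-hydroxyphenyl on a double-bonded chain carbon bound to a double-bonded chain carbon. No measured step touches this ring, so nothing shown predicts a direction. The step of no change at the digits printed from compound 2 to compound 3 (within the scatter) is therefore expected to stay within the scatter. Compound 3 is estimated at 1600 nM, with a range of 500 nM to 5000 nM.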

Compound 3, concentration for 50% growth inhibition: 1260 nM
Estimate against measurement, compound 3: 1.3-fold (0.10 log units) above, within the range that was stated.
By their numbers in this assay, from the lowest: compounds 3 and 2 (each within the scatter of the next); then compound 1.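

In this assay the ring on the double-bonded chain carbon now has a measured step of its own, a 1.3-fold lower number from compound 2 to compound 3 (0.10 log units; within the scatter) with 4-hydroxy-3-methoxyphenyl in place of 3-hydroxyphenyl. At this position, with the chloro group kept on the other aromatic ring, the larger 4-hydroxy-3-methoxyphenyl thus leaves the number within the scatter. Going by these compounds, whether the same holds without the chloro group stays open, as does what an amine or a carboxylic acid on this ring would do. No evidence at hand bears on this result.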